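Swapping chloro for nitro on a chalcone-bearing lactone amide

The compounds below may be only part of what the source reports. "The series", "measured", "known", "first", "only" and "open" are said of these compounds alone.

Three compounds sharing a lactone-bearing core were tested in a functional assay on MGC-803 cells (Homo sapiens) for antiproliferative activity, read by MTT assay, with a stated time of 72 h; a lower number here means a stronger inhibitor, a higher number a weaker inhibitor. Compound 1 `O=C(COc1ccc(C(=O)/C=C/c2cccc(Cl)c2)cc1)N[C@H]1CCOC1=O` gives 29100 nM in this assay. Compound 3 `C=CCc1ccc(OCCSC(=S)N[C@H]2CCOC2=O)c(OC)c1` gives 27900 nM in this assay, and its number and that of compound 1 lie within the usual scatter of each other, so neither can be called stronger. Compound 2 `CCCCCCCCCCSC(=S)N[C@H]1CCOC1=O` reaches only the assay limit of > 64000 nM in this assay, which is a limit and not a number (the limit of > 64000 nM in this assay, at which 1 of the 3 values shown sits). Among the two numbers, compound 1 stands at the higher one.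

Compound 4 `O=C(COc1ccc(C(=O)/C=C/c2cccc([N+](=O)[O-])c2)cc1)N[C@H]1CCOC1=O` has not yet been measured. It differs from compound 1 in one place: nitro in place of chloro on an aromatic carbon. Among the compounds with values here, no measured pair here shows what this exchange on the aromatic ring does, so the expected step is small and without a clear direction. The step from compound 1 to compound 4 is estimated to be a 1.2-fold lower number from compound 1 to compound 4 (0.07 log units; within the scatter), within the scatter. Compound 4 is therefore expected to give about 25000 nM in this assay, with a range from 8000 nM to 80000 nM.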

Compound 4, half-maximal inhibitory concentration: > 64000 nM
Compound 4 ended at the assay's limit; the forecaster's own chance of this, stated with the estimate: 20%; middle value at least 2.5-fold (0.40 log units) away from the limit.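

In this assay, this position on the aromatic ring proves sensitive to the group it carries: nitro in place of chloro gives an at least 2.1-fold higher number from compound 1 to compound 4 (0.34 log units; beyond the scatter), a weakening beyond the usual scatter. This is the only step shown between compounds that differ in one place, and it indicates that the activity of compound 1 depends on what sits on this aromatic carbon, not on the shared core alone. The result for compound 4 is a limit of the assay and not a number: the limit of > 64000 nM in this assay, at which 2 of the 4 values shown sit.

These compounds give no cause for the step, and one exchange cannot tell whether chloro supports the activity or nitro harms it. An amine, a methoxy group or plain hydrogen on the same carbon would help separate those two readings.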